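A Dimethylamino Swap Under a Solubility Limit

The source may report more compounds than this note shows. Statements on the series, on what has been measured and on what is new or still open speak of the compounds shown alone.

In a physicochemical assay for solubility, using the shake flask method, in simulated intestinal fluid, measured as kinetic solubility, with a stated time of 2 h, at 25 degrees C, at pH 6.5 (a higher number here means a more soluble compound, a lower number a less soluble compound), compound 1 (`Cc1noc(-c2nc(C)c3c(c2N)C(=O)N(Cc2ccc(Br)cc2)C3=O)n1`) gives < 5000 nM, a limit of the assay and not a number. Compound 2 (`Cc1noc(-c2nc(C)c3c(c2N)C(=O)N(Cc2ccc(SC(F)(F)F)cc2)C3=O)n1`) gives < 5000 nM, which is also a limit. The record so far is the limit of < 5000 nM in this assay, at which 2 of the 2 values shown sit. Among the measured compounds shown here, the one measured step, a step that the two limits leave unreadable from compound 1 to compound 2, therefore has no readable size. Compound 3 (`Cc1noc(-c2nc(C)c3c(c2N)C(=O)N(Cc2ccc(N(C)C)cc2)C3=O)n1`) carries dimethylamino in place of (trifluoromethyl)sulfanyl on an aromatic carbon. With no readable size in that step, no change beyond the scatter is expected. The expected step is a step that the limit leaves unreadable from compound 2 to compound 3. Compound 3 is estimated at 4000 nM, with an expected range of 1500 nM to 10000 nM.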

Compound 3, solubility: 7400 nM
Compound 3: middle estimate off by 1.9-fold (0.27 log units), on the low side; low and high end bracket the measured number.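

With dimethylamino on this aromatic carbon, para to a large group, compound 3 gives the first number rather than a limit in this assay, and the steps of an at least 1.4-fold higher number from compound 2 to compound 3 (0.17 log units; that floor lies within the scatter) and an at least 1.4-fold higher number from compound 1 to compound 3 (0.17 log units; that floor lies within the scatter) are floors, not sizes. The step from compound 1 to compound 2 still cannot be read, and the record remains mostly limits: the limit of < 5000 nM in this assay, at which 2 of the 3 values shown sit.

The compounds shown leave open whether a morpholine, a primary amine or a carboxylic acid on this carbon would also give a number rather than a limit.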